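This account rests on a few compounds, and the source may have more. Where it says the series, first, only, none or still open, it means among the compounds named here.

Of the compounds shown here, three built on one shared core have been tested in an ADME assay on PANC-1 cells (Homo sapiens) for cytotoxicity, read by MTT assay, with a stated time of 48 h; on this read-out higher numbers stand for weaker inhibition of growth and lower numbers for stronger inhibition of growth. Compound 1 `O=C(/C=C\c1ccc(O)cc1)N1N=C(c2ccncc2)OC1c1c[nH]c2ccccc12` carries a 4-hydroxyphenyl on a double-bonded chain carbon bound to a double-bonded chain carbon, compound 2 `Cc1ccc(/C=C\C(=O)N2N=C(c3ccncc3)OC2c2c[nH]c3ccccc23)cc1` carries a 4-methylphenyl at that place, and compound 3 `O=C(/C=C\c1cccc(F)c1)N1N=C(c2ccncc2)OC1c1c[nH]c2ccccc12` carries a 3-fluorophenyl there. In this assay compound 1 gives only a limit, > 30 ug/mL, not a number. Compound 2 also stops at a limit, > 30 ug/mL. Compound 3 stops at a limit as well, > 30 ug/mL. All three share (the limit of > 30 ug/mL in this assay, at which 3 of the 3 values shown sit), so the change from compound 1 to compound 2, a step that the two limits leave unreadable from compound 1 to compound 2, and the change from compound 2 to compound 3, a step that the two limits leave unreadable from compound 2 to compound 3, cannot be sized.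

Compound 4 `O=C(/C=C\c1ccc(Cl)cc1Cl)N1N=C(c2ccncc2)OC1c1c[nH]c2ccccc12` has not yet been measured. It differs from compound 2 by 2,4-dichlorophenyl in place of 4-methylphenyl on a double-bonded chain carbon bound to a double-bonded chain carbon. The steps that touch compound 2 are the ones that bear on this change, and both are unreadable. With no readable step to lean on, no direction can be expected beyond the scatter, and another limit is the most likely outcome. Compound 4 is therefore expected to give 30 ug/mL in this assay, within a range from 12 ug/mL to 60 ug/mL. The step so expected, a number no higher from compound 2 to compound 4 (the limit leaves the size open), amounts to none beyond the scatter.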

Compound 4, concentration for 50% growth inhibition: > 30 ug/mL
Compound 4: a limit, no number; the forecaster's own chance of this, stated with the estimate: 65%; the middle value sits exactly at the limit.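

Compound 4 gives only a limit, > 30 ug/mL, not a number. Its steps from compound 1, compound 2 and compound 3 therefore cannot be read, and all four compounds end at the same point: the limit of > 30 ug/mL in this assay, at which 4 of the 4 values shown sit. The compounds shown leave open how strongly any of them inhibits growth in this assay, and whether changing this aromatic group alters that at all.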